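The compounds below may be only part of what the source reports. "The series", "measured", "known", "first", "only" and "open" are said of these compounds alone.

Compound 1, `COCc1ccc(-n2c(SC(C)c3ccccc3)nc3c(cnn3C)c2=O)cc1`, was tested in an assay on isolated protein for inhibition of retinal dehydrogenase 2 (Homo sapiens), tested at 5 uM (a lower number here means less inhibition, a higher number more inhibition at the concentration tested (going by the name of the read-out)), where compound 1 gives 61%. Among the measured compounds shown here, the only other measured compound, compound 2, `CC(Sc1nc2c(cnn2C)c(=O)n1-c1ccccc1)c1ccncc1`, gives 69% in this assay. The gap between these two numbers lies within the usual scatter of repeated measurements, so compound 1 stands alongside compound 2 rather than apart from it. Compound 3, `CC(Sc1nc2c(cnn2C)c(=O)n1-c1ccc(CN(C)C)cc1)c1ccccc1`, has not yet been measured. It differs from compound 1 in one place: dimethylamino in place of methoxy on a saturated chain carbon bound to an aromatic carbon. For the measured compounds named here, no measured pair shows what this change does to inhibition, so there is no step to read from. Without such a step, the expectation is a change no larger than the scatter, in either direction, and the estimated step is a number 1 percentage points higher from compound 1 to compound 3 (within the scatter). Compound 3 is therefore expected to give about 62% in this assay, with a likely range from 45% to 78%.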

Compound 3, a percentage reported as inhibition, at one concentration (the size of the read-out at that concentration, not a potency): 86%
Compound 3: the middle estimate sits 24 percentage points below what was measured; measured number above the stated range.
By their numbers in this assay, from the lowest: compounds 1 and 2 (each within the scatter of the next); then compound 3.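

In this assay, among the compounds shown here, dimethylamino in place of methoxy on a saturated chain carbon bound to an aromatic carbon gives a number 25 percentage points higher from compound 1 to compound 3 (beyond the scatter) and is the first step in this set to stand clear of the scatter. This shows that inhibition at the tested concentration responds to what sits at this place, even when the rest of compound 1 stays untouched. What lies behind the rise cannot be said, as no supporting measurement accompanies these numbers.

The compounds shown leave open whether the gain needs the nitrogen with its two methyl groups, since no primary amine, pyrrolidine or morpholine at this place appears among them. A single percentage at one concentration also leaves open how compound 3 compares in potency with compound 1.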